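Two Cores, One Exchange: From Iodophenyl to Naphthyl

A few compounds are considered here, and "the series" means these few. Any claim that something is new, unique, unknown or untested is made for them only; others in the source may bear on it.

Measured compounds:
- compound 1, `CN(c1ccc(NC(=O)c2ccc(I)cc2)cc1OCc1cc(Cl)ccc1Cl)S(C)(=O)=O`, 660 nM
- compound 2, `CN(c1ccc(NC(=O)c2ccc3ccccc3c2)cc1OCc1cc(Cl)ccc1Cl)S(C)(=O)=O`, 2210 nM
- compound 3, `Cc1ccc(C)c(COc2cc(NC(=O)c3ccc(I)cc3)ccc2N(C)S(=O)(=O)C(F)(F)F)c1`, 13500 nM

All three were tested in a functional assay on SK-BR-3 cells (Homo sapiens) for antiproliferative activity, read by MTT assay, with a stated time of 48 h; a higher number here means a weaker inhibitor, a lower number a stronger inhibitor. Compound 1 and compound 2 share one core and differ only at the carbonyl carbon of the amide: naphthalen-2-yl in place of 4-iodophenyl on a carbonyl carbon. That exchange gave a 3.3-fold higher number from compound 1 to compound 2 (0.52 log units; beyond the scatter). Compound 3 carries a different core; the difference between the two cores is not broken down here. Among the three, compound 3 gives the highest number, beyond the scatter from both compound 2 and compound 1.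

Compound 4, `Cc1ccc(C)c(COc2cc(NC(=O)c3ccc4ccccc4c3)ccc2N(C)S(=O)(=O)C(F)(F)F)c1`, has not yet been measured. It stands to compound 3 as compound 2 stands to compound 1: naphthalen-2-yl in place of 4-iodophenyl on a carbonyl carbon. The place is the same, so this is the same change, not merely the same kind.

For the measured compounds named here, with only one earlier instance of this exchange to lean on, the expectation for compound 4 rests on that single step: since a 3.3-fold higher number from compound 1 to compound 2 (0.52 log units; beyond the scatter) in this assay, compound 4 is expected to show a step of about a 3.0-fold higher number from compound 3 to compound 4 (0.47 log units; beyond the scatter) from compound 3. Whether a different core carries the exchange the same way is not known from these data, so the range is kept wide. Compound 4 is estimated at 40000 nM, with a likely span from 15000 nM to 120000 nM.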

Compound 4, half-maximal inhibitory concentration: 41400 nM
The estimate for compound 4 lay 1.0-fold (0.01 log units) below the measured number, and the stated range covers the measured number.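

In this assay, putting naphthalen-2-yl in place of 4-iodophenyl on the carbonyl carbon gave a 3.1-fold higher number from compound 3 to compound 4 (0.49 log units; beyond the scatter). This exchange costs a similar amount of activity on both cores, so the step measured on the core of compound 1 was a usable guide to the step on the core of compound 3, as the two steps show: the same change on two cores in this assay, a 3.3-fold higher number (0.52 log units; beyond the scatter) from compound 1 to compound 2 and a 3.1-fold higher number (0.49 log units; beyond the scatter) from compound 3 to compound 4, 1.1-fold (0.04 log units) apart, within the scatter of two such steps. Still, this is one exchange on just two cores, so it does not show that a third core would respond in the same way, that other exchanges would carry over equally well, or why naphthalen-2-yl gives the higher number in these cells.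

The compounds shown place only these two groups on the carbonyl carbon, leaving open how a plain phenyl, a 4-chlorophenyl or a pyridine ring would behave on either core. From the compounds shown here alone, the two cores also differ in more than one part, so it remains open what a single exchange within the core would do, such as a methyl in place of the trifluoromethyl on the sulfonyl with everything else kept the same.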